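Removing the benzoyl ester of compound 1: an expectation

A few compounds are considered here, and "the series" means these few. Any claim that something is new, unique, unknown or untested is made for them only; others in the source may bear on it.

The series is assessed in a functional assay on U-118-MG cells (Homo sapiens) for cytotoxicity, read by MTT assay, with a stated time of 48 h; on this read-out lower numbers stand for stronger inhibition and higher numbers for weaker inhibition. Compound 1 `O=C(O[C@H]1C[C@H](n2cc(F)c(=O)[nH]c2=O)O[C@@H]1COP(=O)(O)Oc1ccccc1)c1ccccc1` gives 970 nM in this assay, the lowest of the two numbers recorded. Going by the values given here, its nearest neighbour, compound 2 `CCCCCCCCCc1ccc(OP(=O)(O)OC[C@H]2O[C@@H](n3cc(F)c(=O)[nH]c3=O)C[C@@H]2OC(=O)c2ccccc2)cc1`, gives 11000 nM in this assay, and the single measured step, nonyl in place of hydrogen on an aromatic carbon, is an 11-fold higher number from compound 1 to compound 2 (1.05 log units; beyond the scatter).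

Compound 3 `O=c1[nH]c(=O)n([C@H]2C[C@H](O)[C@@H](COP(=O)(O)Oc3ccccc3)O2)cc1F` differs from compound 1 in another place: hydrogen in place of benzoyl on an oxygen on a saturated carbon. Among the compounds with values here, no measured step touches this oxygen; the only step recorded concerns the aromatic carbon, so it cannot guide the size or direction here. With nothing to lean on, a step no larger than the scatter is expected, with a wide margin either way. Compound 3 is therefore estimated at 1500 nM, within 400 nM to 6000 nM. This estimate amounts to an expected 1.5-fold higher number from compound 1 to compound 3 (0.19 log units; within the scatter).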

Compound 3, half-maximal inhibitory concentration: 14600 nM
Compound 3: the middle estimate sits 9.7-fold (0.99 log units) below what was measured; the whole stated range lies below it.
By their numbers in this assay, from the lowest: compound 1; then compounds 2 and 3 (each within the scatter of the next).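

Hydrogen in place of benzoyl on this oxygen on a saturated carbon is not a neutral change in this assay: it gives a 15-fold higher number from compound 1 to compound 3 (1.18 log units; beyond the scatter), so this position responds strongly to what it carries. With this result, both single changes shown from compound 1 lead to a higher number beyond the scatter, one at the aromatic carbon and one at this oxygen. No measurement at hand accounts for the loss seen on removing the benzoyl group.

Going by these compounds, it remains open whether the aromatic ring of the benzoyl group matters or whether any ester at this oxygen would give a number close to that of compound 1, a question that an acetyl ester would address. An amine in place of the hydroxy of compound 3 would show whether this position tolerates other small groups.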